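Amide variation on a shared core: methoxy to chloro

The source may hold more compounds than are shown below. What is called first, only, known or untested is meant among the compounds shown, and "the series" means these compounds.

Measured compounds:
compound 1, `O=C(NN1CCOCC1)c1c(O)c2cccnc2n(-c2ccccc2)c1=O`: -26.2%
compound 2, `COc1ccc(NC(=O)c2c(O)c3cccnc3n(-c3ccccc3)c2=O)cc1`: -1.9%

Both numbers come from a functional assay on the whole organism for inhibition, with Rattus norvegicus as the target, read by cytopathic effect and paw edema, at a dose of 100 mg/kg by the oral route; on this read-out lower numbers stand for less inhibition and higher numbers for more inhibition at the one dose given (going by the name of the read-out). For the measured compounds named here, compound 2 stands highest of the two, and the only step in the set, a number 24.3 percentage points higher from compound 1 to compound 2 (beyond the scatter), separates it from compound 1; that step exchanges morpholin-4-yl for 4-methoxyphenyl on an amide-type nitrogen.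

Compound 3, `O=C(Nc1ccc(Cl)cc1)c1c(O)c2cccnc2n(-c2ccccc2)c1=O`, keeps the shared core and the amide-type nitrogen carrying an aromatic ring, and differs from compound 2 as follows: chloro in place of methoxy on an aromatic carbon. Going by the values given here, the only measured step exchanges the whole group on the amide-type nitrogen and does not exchange one substituent on an aromatic carbon for another, so it bears on the present change only loosely. Among the compounds with values here, no measured pair shows what chloro in place of methoxy does on this core. With nothing directly comparable, no step beyond the scatter is expected in this assay, and the estimate for compound 3 is 0%, within -20% to 20%, which is expected to mean a step of a number 1.9 percentage points higher from compound 2 to compound 3 (within the scatter).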

Compound 3, a percentage reported as inhibition, in the whole organism at one dose (the size of the read-out at that dose, not a potency): 2.5%
Estimate against measurement, compound 3: 2.5 percentage points below, and the stated range covers the measured number.
By their numbers in this assay, from the lowest: compound 1; then compounds 2 and 3 (each within the scatter of the next).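

Working notes on the aromatic amides: in this assay the exchange of methoxy for chloro on an aromatic carbon, para to a large group, gives a number 4.4 percentage points higher from compound 2 to compound 3 (within the scatter) and so does not separate the two compounds, which means this substituent change has no readable effect at the one dose given. The gap to the morpholin-4-yl amide holds with the new group as well, with 4-chlorophenyl in place of morpholin-4-yl on the amide-type nitrogen giving a number 28.7 percentage points higher from compound 1 to compound 3 (beyond the scatter) and thus a second case, after compound 2, of an aromatic ring on that nitrogen standing above compound 1 by more than the scatter. Nothing at hand offers an explanation for either step.

From the compounds shown here alone, whether any group at this aromatic carbon can move the number beyond the scatter remains open, since a carboxylic acid or a dimethylamino group there would test a much wider change than chloro for methoxy. Also open, going by these compounds, is whether the aromatic ring itself matters on the amide-type nitrogen or whether a plain alkyl chain such as n-butyl would stand at the same level.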